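Compound 4: methoxy in place of tert-butyl

This account rests on a few compounds, and the source may have more. Where it says the series, first, only, none or still open, it means among the compounds named here.

Measured in an ADME assay on TERT-RPE1 cells (Homo sapiens) for cytotoxicity, read by MTT assay, with a stated time of 72 h; on this read-out higher numbers stand for weaker inhibition and lower numbers for stronger inhibition:
- compound 1 `C=C1CN(C)/C(=N/c2ccccc2)S1`: > 100000 nM (a limit of the assay, not a number)
- compound 2 `COc1ccc(/C=C2/CN(C)/C(=N/c3ccc(F)cc3)S2)cc1`: 42800 nM
- compound 3 `COc1ccc(/C=C2\S/C(=N\c3ccc(C(C)(C)C)cc3)N(C)C2=O)cc1`: 46700 nM

Compound 3 is the starting point for the next comparison. Compound 3 gives 46700 nM and compound 2 gives 42800 nM, and these two values lie within the usual scatter of each other. Compound 1 has only a limit, > 100000 nM, and no number that can be placed beside them.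

Compound 4 `COc1ccc(/C=C2\S/C(=N\c3ccc(OC)cc3)N(C)C2=O)cc1` has not yet been measured. Its difference from compound 3 is methoxy in place of tert-butyl on an aromatic carbon. In words, methoxy stands in place of tert-butyl on an aromatic carbon, para to a large group.

Among the compounds with values here, no measured step covers this change, so any expectation in this assay is loose. The anchor is compound 3 at 46700 nM. A small move is expected, probably within the scatter, with a slight lean towards a higher number. The expected size of the change is a 1.2-fold higher number from compound 3 to compound 4 (0.07 log units; within the scatter). A result reported only as a limit remains possible. For compound 4 the estimated value is 55000 nM, with an expected range of 24000 nM to 100000 nM.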

Compound 4, half-maximal inhibitory concentration: > 100000 nM
Compound 4 was reported as a limit; the forecaster's own chance of this, stated with the estimate: 20%; middle value at least 1.8-fold (0.25 log units) away from the limit.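

In this assay, within the data shown here, methoxy in place of tert-butyl on an aromatic carbon, para to a large group, gives an at least 2.1-fold higher number from compound 3 to compound 4 (0.33 log units; beyond the scatter), the first step that can be read between compounds differing in one place. The group at this position therefore matters to the read-out, and the direction is towards weaker inhibition on going from tert-butyl to methoxy. Compound 4 stands at a limit and not at a number, so the step gives only a lower bound on the size of the change: the limit of > 100000 nM in this assay, at which 2 of the 4 values shown sit.

Going by these compounds, how far compound 4 lies past that limit stays unknown, and with only tert-butyl and methoxy at this position, one step cannot show whether the trend follows the size of the group, the oxygen or something else. An amine, a carboxylic acid or a longer alkyl chain on the same aromatic carbon would be needed to separate these readings, ideally with values that fall inside the range of the assay.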